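Trimming the Chain of a Trifluoromethyl Ketone Inhibitor

The source may report more compounds than this note shows. Statements on the series, on what has been measured and on what is new or still open speak of the compounds shown alone.

Compound 3 `CCCCCCCCCCCCCC(=O)C(F)(F)F` holds the second highest of the three numbers recorded so far in an assay on isolated protein for inhibition of Fatty-acid amide hydrolase 1 (Homo sapiens); on this read-out higher numbers stand for weaker inhibition and lower numbers for stronger inhibition. Compound 3 gives 490 nM, while compound 1 `CCCCCCCCCCCCCCCCCC(=O)C(F)(F)F` gives 240 nM and compound 2 `CCCCCC(=O)C(F)(F)F` gives 28900 nM. Compound 4 `CCCCCCCCCC(=O)C(F)(F)F` differs from compound 3 by hydrogen in place of butyl on a saturated chain carbon, nine bonds along the chain from a carbonyl carbon. Going by the values given here, the one comparable step already measured is a 2.0-fold higher number from compound 1 to compound 3 (0.31 log units; beyond the scatter), the same kind of trimming applied to the next longer chain. Compound 2, trimmed yet again in the same manner, shows a far higher number than compound 3, so the loss is expected to grow as the chain shrinks. The step to compound 4 is therefore expected to be a 5.1-fold higher number from compound 3 to compound 4 (0.71 log units; beyond the scatter). Compound 4 is estimated at 2500 nM, within a range from 800 nM to 8000 nM.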

Compound 4, inhibition constant: 130 nM
Compound 4: the middle estimate sits 19-fold (1.28 log units) above what was measured, outside the stated range (below it).
By their numbers in this assay, from the lowest: compounds 4 and 1 (each within the scatter of the next); then compound 3; then compound 2.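

Shortening the chain at this position lowers the number rather than raising it: in this assay the loss of butyl gives a 3.8-fold lower number from compound 3 to compound 4 (0.58 log units; beyond the scatter) here, so the number does not climb steadily as the chain shortens. Adding butyl to the shortest chain gives a 220-fold lower number from compound 2 to compound 4 (2.35 log units; beyond the scatter) in the same assay, yet compound 3 goes against any simple rule that longer chains give lower numbers. The size of this change depends heavily on the chain that carries it: the same change on two cores in this assay, a 2.0-fold higher number (0.31 log units; beyond the scatter) from compound 1 to compound 3 and a 220-fold higher number (2.35 log units; beyond the scatter) from compound 4 to compound 2, 110-fold (2.04 log units) apart, beyond the scatter of two such steps 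

Going by these compounds, whether a longer chain would lower the number further remains open. So does the effect of a carboxylic acid in place of the trifluoromethyl ketone.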